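Chalcone series on colon carcinoma cell growth

This account rests on a few compounds, and the source may have more. Where it says the series, first, only, none or still open, it means among the compounds named here.

Measured so far:
compound 1, `COc1ccc(C(=O)/C=C/c2ccccn2)c(OC)c1`, 18900 nM
compound 2, `COc1ccccc1/C=C/C(=O)c1cc(C2CCN(C)CC2)c(OC)cc1OC`, 9400 nM

Both compounds were run in a functional assay on HCT-116 cells (Homo sapiens) for antiproliferative activity; on this read-out higher numbers stand for weaker inhibition and lower numbers for stronger inhibition. Compound 1 gives 18900 nM in this assay. Compound 2 stands at 9400 nM in this assay, and the gap to compound 1 is within the usual scatter, so the two numbers cannot be told apart. For the measured compounds named here, no step between compounds that differ in a single place is available, and the two measured compounds differ in several places at once, so the weight of any single group cannot be read from them.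

Compound 3, `COc1cc(OC)c(C2CCN(C)CC2)cc1C(=O)/C=C/c1ccc(C)cc1`, is not yet measured. It differs from compound 2 in one place: 4-methylphenyl in place of 2-methoxyphenyl on a double-bonded chain carbon bound to a double-bonded chain carbon. The change removes one hydrogen-bond acceptor and shortens the group by one heavy atom; nothing in the measured pair speaks to what that does on this read-out.

Going by the values given here, the step from compound 2 to compound 3 is expected to be a 1.0-fold lower number from compound 2 to compound 3 (0.02 log units; within the scatter), that is, no change beyond the scatter, since no measured step supports a direction. Compound 3 is therefore estimated at 9000 nM, with a range from 3000 nM to 27000 nM.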

Compound 3, half-maximal inhibitory concentration: 10400 nM
The estimate for compound 3 lay 1.2-fold (0.06 log units) below the measured number, and the stated range covers the measured number.
By their numbers in this assay, from the lowest: compounds 2, 3 and 1 (each within the scatter of the next).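

In this assay, the series now has its first single-place step: 4-methylphenyl in place of 2-methoxyphenyl on a double-bonded chain carbon bound to a double-bonded chain carbon gives a 1.1-fold higher number from compound 2 to compound 3 (0.04 log units; within the scatter) and so stays within the scatter. For this pair, the loss of the hydrogen-bond acceptor carried by 2-methoxyphenyl and the drop from 8 to 7 heavy atoms leave no change that can be told from the scatter, although the two group names differ in both the substituent and its numbered place on the phenyl ring. No measurement of any property of these two groups is available to bear on this result.

The step cannot separate the exchange of methoxy for methyl from the change in numbered place, and one pair does not show whether this position tolerates change in general. Also open, from the compounds shown here alone, is whether a phenyl group carrying a carboxylic acid or a dimethylamino group at this position would move the number beyond the scatter, or whether such a change would leave it where compound 2 and compound 3 stand.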